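This account rests on a few compounds, and the source may have more. Where it says the series, first, only, none or still open, it means among the compounds named here.

Compound 2 `O=C(Nc1cccc(-n2cc(-c3ccncc3)c(-c3cc(O)cc(Cl)c3)n2)c1)Nc1ccc(Cl)c(Cl)c1` is one of three closely related compounds measured in a functional assay on PC-3 cells (Homo sapiens) for inhibition, read by sulforhodamine B assay, with a stated time of 48 h, tested at 1 uM; a higher number here means a weaker effect of the compound at the concentration tested, a lower number a stronger effect. Among the compounds with values here, compound 1 `O=C(Nc1cccc(-n2cc(-c3ccncc3)c(-c3cc(O)cc(Cl)c3)n2)c1)Nc1ccc(Cl)c(C(F)(F)F)c1` gives 83%, while compound 2 gives 72%, and the single measured change between them, a number 11 percentage points lower from compound 1 to compound 2 (beyond the scatter), is a modest step. Compound 3 `COc1cc(Cl)cc(-c2nn(-c3cccc(NC(=O)Nc4cc(C(F)(F)F)cc(C(F)(F)F)c4)c3)cc2-c2ccncc2)c1` gives 5%. Compound 2 therefore stands second highest of the three numbers, close to compound 1 and far from compound 3.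

Compound 4 `COc1cc(Cl)cc(-c2nn(-c3cccc(NC(=O)Nc4ccc(Cl)c(Cl)c4)c3)cc2-c2ccncc2)c1` differs from compound 2 in one place: methyl in place of hydrogen on an oxygen on an aromatic ring. Within the data shown here, no measured step covers this change by itself. The step of a number 11 percentage points lower from compound 1 to compound 2 (beyond the scatter) concerns a different part of the molecule and offers no guide. Compound 3 carries the same methoxy, but it also carries a different aryl on the urea, so the wide gap between compound 2 and compound 3 cannot be split between the two changes. The step in this assay is expected to be a number 27 percentage points lower from compound 2 to compound 4 (beyond the scatter), with its size uncertain. Compound 4 is accordingly estimated at 45%, within a range from 10% to 75%.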

Compound 4, a percentage reported as activity, at one concentration (the size of the read-out at that concentration, not a potency): 54%
The estimate for compound 4 lay 9 percentage points below the measured number; low and high end bracket the measured number.
By their numbers in this assay, from the lowest: compound 3; then compound 4; then compound 2; then compound 1.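

In this assay, within the data shown here, replacing hydroxy with methoxy on the 3-chloro-5-hydroxyphenyl group gives a number 18 percentage points lower from compound 2 to compound 4 (beyond the scatter), the first direct reading of this change and one that shows a stronger effect with the methyl on this oxygen. Compound 4, at 54%, still lies far from compound 3, at 5%; these two share the methoxy and differ only in the aryl on the urea, so the methoxy alone does not bring the number down to that of compound 3, and the aryl on the urea also matters. No measurement available here explains the step.

On these data alone, whether a longer chain on this oxygen, such as ethoxy, or an amine in place of the methoxy would lower the number further remains open. So does whether the step keeps its size with a different aryl on the urea.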